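Formyl to hydroxymethyl: what compound 3 may show

The compounds below may be only part of what the source reports. "The series", "measured", "known", "first", "only" and "open" are said of these compounds alone.

In a functional assay on T29Kt1 cells (Homo sapiens) for cytotoxicity, read by sulforhodamine B assay, with a stated time of 3 days (a higher number here means a weaker inhibitor, a lower number a stronger inhibitor), compound 1 (`O=Cc1cn(Cc2ccc(Cl)cc2Cl)c2ccccc12`) gives 1580 nM. That is the higher of the two numbers available, and the gap to the other lies beyond the scatter: compound 2 (`O=[N+]([O-])c1ccc(Cn2cc(CO)c3ccccc32)cc1`) gives 150 nM. Compound 3 (`OCc1cn(Cc2ccc(Cl)cc2Cl)c2ccccc12`) keeps the core of compound 1 and its other substituent, but has hydroxymethyl in place of formyl on an aromatic carbon.

For the measured compounds named here, no measured pair isolates this change, so the expectation rests on thin evidence. Compound 2 also carries hydroxymethyl and gives 150 nM, though it differs from compound 3 in its other substituent too. A lower number in this assay, beyond the scatter, is therefore expected. The expected step is a 5.3-fold lower number from compound 1 to compound 3 (0.72 log units; beyond the scatter). For compound 3 the estimated value is 300 nM, with an expected range of 60 nM to 1200 nM.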

Compound 3, half-maximal inhibitory concentration: 1580 nM
The estimate for compound 3 lay 5.3-fold (0.72 log units) below the measured number; measured number outside the range, above it.
By their numbers in this assay, from the lowest: compound 2; then compounds 1 and 3 (each within the scatter of the next).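

In this assay hydroxymethyl in place of formyl on this aromatic carbon brings no change at the digits printed from compound 1 to compound 3 (within the scatter) and so, with the other substituent of compound 1 held fixed, this exchange of one hydrogen-bond donor for a double bond outside aromatic rings leaves the number where it was. Hydroxymethyl alone therefore does not go with the lower number, since compound 3 gives 1580 nM and compound 2 gives 150 nM while the two differ only in their other substituent. Nothing available accounts for the absence of a change at this position.

Going by these compounds, whether a carboxylic acid or an aminomethyl group on this aromatic carbon would also leave the number unchanged remains open. So does whether formyl in place of hydroxymethyl would matter alongside the other substituent of compound 2.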